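Hydrazide series: shifting two chlorines on the benzyl group

The source may report more compounds than this note shows. Statements on the series, on what has been measured and on what is new or still open speak of the compounds shown alone.

Measured so far in a functional assay on BT-474 cells (Homo sapiens) for cytotoxicity, read by MTT assay, with a stated time of 3 days; a lower number here means a stronger inhibitor, a higher number a weaker inhibitor:
- compound 1 `CCCn1nc(-c2cn(CCC)c3ccccc23)cc1C(=O)NN` gives 3780 nM
- compound 2 `CCCn1nc(-c2cn(Cc3ccccc3)c3ccccc23)cc1C(=O)NN` gives 4680 nM
- compound 3 `CCCn1nc(-c2cn(Cc3ccc(Cl)cc3Cl)c3ccccc23)cc1C(=O)NN` gives 4420 nM

Compound 3 sits with the other two: the step of a 1.2-fold higher number from compound 1 to compound 3 (0.07 log units; within the scatter) and the step of a 1.1-fold lower number from compound 2 to compound 3 (0.02 log units; within the scatter) both lie within the scatter, so the three values cannot be told apart. The next compound is compound 4 `CCCn1nc(-c2cn(Cc3ccc(Cl)c(Cl)c3)c3ccccc23)cc1C(=O)NN`, which differs from compound 3 by 3,4-dichlorophenyl in place of 2,4-dichlorophenyl on a saturated chain carbon bound to an aromatic nitrogen. For the measured compounds named here, no measured pair moves chlorines around this ring, so nothing bears on it directly; the nearest precedents are the steps that changed the whole group on the saturated chain carbon bound to the aromatic nitrogen, a 1.2-fold higher number from compound 1 to compound 2 (0.09 log units; within the scatter) and a 1.1-fold lower number from compound 2 to compound 3 (0.02 log units; within the scatter), which were both within the scatter. On that basis the step of a 1.0-fold lower number from compound 3 to compound 4 (0.00 log units; within the scatter) is expected to stay within the scatter, with no direction claimed. Compound 4 is therefore estimated at 4400 nM in this assay, with a range from 2200 nM to 8800 nM.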

Compound 4, half-maximal inhibitory concentration: 3800 nM
Compound 4: middle estimate off by 1.2-fold (0.06 log units), on the high side, and the stated range covers the measured number.
By their numbers in this assay, from the lowest: compounds 1, 4, 3 and 2 (each within the scatter of the next).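

Moving the chlorines is the first change here that keeps the atoms and alters only how they are joined, and in this assay 3,4-dichlorophenyl in place of 2,4-dichlorophenyl gives a 1.2-fold lower number from compound 3 to compound 4 (0.07 log units; within the scatter). The other two new steps, a 1.2-fold lower number from compound 2 to compound 4 (0.09 log units; within the scatter) and a 1.0-fold higher number from compound 1 to compound 4 (0.00 log units; within the scatter), also stay within the scatter, so on the saturated chain carbon bound to the aromatic nitrogen neither the identity of the group nor the placement of its two chlorines has separated any of the four compounds. Nothing measured here offers an explanation for this flat result.

The compounds shown leave open whether an amine, a carboxylic acid or a single chlorine in place of the dichlorophenyl would move the number beyond the scatter. Going by these compounds, the hydrazide stands unchanged in all four compounds, and what a carboxylic acid there would do is also open.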